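A Repeated Group Swap in an Antiproliferative Series

A few compounds are considered here, and "the series" means these few. Any claim that something is new, unique, unknown or untested is made for them only; others in the source may bear on it.

Three compounds were measured in a functional assay on CWR22R cells (Homo sapiens) for antiproliferative activity, read by propidium iodide staining, with a stated time of 96 h; on this read-out lower numbers stand for stronger inhibition and higher numbers for weaker inhibition. Compound 1 `CC(O)(COc1cccc(S(F)(F)(F)(F)F)c1)C(=O)Nc1ccc(S(F)(F)(F)(F)F)cc1` gives 17600 nM in this assay. Compound 2 `CC(O)(COc1cccc(C(F)(F)F)c1)C(=O)Nc1ccc(S(F)(F)(F)(F)F)cc1`, which carries a group of 4 heavy atoms (1 carbon, 3 fluorine; no ring) in place of a group of 6 heavy atoms (5 fluorine, 1 sulfur; no ring), on an aromatic carbon, gives 14600 nM in this assay, so the swap made a 1.2-fold lower number from compound 1 to compound 2 (0.08 log units; within the scatter). Compound 3 `CC(O)(COc1ccc(S(F)(F)(F)(F)F)cc1)C(=O)Nc1cccc(S(F)(F)(F)(F)F)c1` is built from the same atoms as compound 1, joined differently; the difference between the two cores is not broken down here. In this assay compound 3 gives 10200 nM, a number that lies within the usual scatter of both compound 1 and compound 2, so the three numbers cannot be put in any order.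

Compound 4 `CC(O)(COc1ccc(C(F)(F)F)cc1)C(=O)Nc1cccc(S(F)(F)(F)(F)F)c1` has not yet been measured. Relative to compound 3 it carries a group of 4 heavy atoms (1 carbon, 3 fluorine; no ring) in place of a group of 6 heavy atoms (5 fluorine, 1 sulfur; no ring), on an aromatic carbon. Going by the values given here, this is the same kind of change as the one from compound 1 to compound 2, but not the same: in compound 2 the trifluoromethyl sits meta to a large group, while in compound 4 it sits para to a large group.

Because the earlier swap produced a 1.2-fold lower number from compound 1 to compound 2 (0.08 log units; within the scatter), the step from compound 3 to compound 4 in this assay is expected to be a 1.2-fold lower number from compound 3 to compound 4 (0.08 log units; within the scatter). Compound 4 is therefore estimated to give 8500 nM in this assay. The expected range for compound 4 runs from 4000 nM to 18000 nM.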

Compound 4, half-maximal inhibitory concentration: 3600 nM
The estimate for compound 4 lay 2.4-fold (0.37 log units) above the measured number; the whole stated range lies above it.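

In this assay, putting trifluoromethyl in place of the sulfur group with its five fluorines gave a 2.8-fold lower number from compound 3 to compound 4 (0.45 log units; beyond the scatter), a modest step, while the same swap on the other core gave a 1.2-fold lower number from compound 1 to compound 2 (0.08 log units; within the scatter). Set side by side, the two steps cannot be told apart: the same change on two cores in this assay, a 1.2-fold lower number (0.08 log units; within the scatter) from compound 1 to compound 2 and a 2.8-fold lower number (0.45 log units; beyond the scatter) from compound 3 to compound 4, 2.4-fold (0.37 log units) apart, within the scatter of two such steps. So nothing here shows the swap behaving differently on the two cores, but two pairs cannot show that it has one fixed size in this series, and the step on the core of compound 1 stays too small to count as a real change in either direction.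

The compounds shown leave open how a nitrile, a chlorine atom or a methyl group would fare on the same aromatic carbon, and whether the swap would give a similar step on the ring attached to the amide nitrogen. They also leave open whether the step seen for compound 4, where the trifluoromethyl sits para to a large group, depends on that place, since the two pairs differ in more than the swap itself.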